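The source may report more compounds than this note shows. Statements on the series, on what has been measured and on what is new or still open speak of the compounds shown alone.

Working notes on the series. In a functional assay on the whole organism (strain Swiss) with Mus musculus as the target, in the maximal electroshock model, with a stated time of 0.25 h (a higher number here means that more compound is needed for the effect, a lower number that less compound is needed), compound 1 `COCC(C(=O)N1CCN(c2cccc(C(F)(F)F)c2)CC1)N1C(=O)CCC1=O` gives 58.1 mg/kg. Among the measured compounds shown here, compound 2 `CC(C(=O)N1CCN(c2ccccc2)CC1)N1C(=O)CCC1=O` gives 165 mg/kg in this assay, the highest number of the two; the only other value, that of compound 1, lies below it by a gap beyond the scatter. Compound 3 `CC(C(=O)N1CCN(c2ccccc2F)CC1)N1C(=O)CCC1=O` is not yet measured in this assay. The change from compound 2 to compound 3 is fluoro in place of hydrogen on an aromatic carbon. For the measured compounds named here, no measured pair shows this change, so no step is known for it; a step not clearly beyond the scatter is expected in either direction. For compound 3 the expected value in this assay is 130 mg/kg, between 60 mg/kg and 300 mg/kg, a step of a 1.3-fold lower number from compound 2 to compound 3 (0.10 log units; within the scatter).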

Compound 3, dose for half-maximal effect: 151 mg/kg
Compound 3: middle estimate off by 1.2-fold (0.07 log units), on the low side; the range from low to high includes it.
By their numbers in this assay, from the lowest: compound 1; then compounds 3 and 2 (each within the scatter of the next).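

Among the compounds shown here, the first measured step for this change is a 1.1-fold lower number from compound 2 to compound 3 (0.04 log units; within the scatter) in this assay, so a fluoro on an aromatic carbon ortho to a large group gives no step beyond the scatter. The earlier compounds shown here differ in more than one place and could not isolate this position. No measurement at hand explains the size of this step.
Going by these compounds, whether a chloro or a methoxy at this position also stays within the scatter remains open. The number of compound 1 also cannot be assigned to any single group.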